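A few compounds are considered here, and "the series" means these few. Any claim that something is new, unique, unknown or untested is made for them only; others in the source may bear on it.

Measured so far in an assay on cells for displacement of a labelled ligand from adenosine receptor A1 (Homo sapiens), read by radioligand binding, with a stated time of 60 min, tested at 1 uM; a higher number here means more inhibition at the concentration tested (going by the name of the read-out), a lower number less inhibition:
compound 1 `CC(C)OC(=O)C1=C(C(F)(F)F)NC(=O)NC1c1ccsc1` gives 23%;
compound 2 `CCOC(=O)C1=C(C(F)(F)F)NC(=O)NC1c1ccsc1` gives 32%.

For the measured compounds named here, compound 1 is one of only two measured compounds. Going by the values given here, its single neighbour differs at the ester, where the step of a number 9 percentage points higher from compound 1 to compound 2 (within the scatter) stays within the scatter, so the two read-outs cannot be told apart.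

Compound 3 `CC(C)OC(=O)C1=C(C(F)(F)F)NC(=O)NC1c1cccs1` is built from compound 1 by thiophen-2-yl in place of thiophen-3-yl on a saturated ring carbon. Among the compounds with values here, no measured step touches this change: the one step recorded, from compound 1 to compound 2, alters the ester and leaves the thiophene untouched, so it carries no information about swapping thiophen-3-yl for thiophen-2-yl. Without a precedent, the expected step is a number 3 percentage points higher from compound 1 to compound 3 (within the scatter), that is, none beyond the scatter in either direction in this assay. Compound 3 is therefore estimated at 26%, with a wide range from 5% to 55%.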

Compound 3, a percentage reported as inhibition, at one concentration (the size of the read-out at that concentration, not a potency): 8%
For compound 3 the middle estimate is 18 percentage points above the measured one, and the stated range covers the measured number.
By their numbers in this assay, from the lowest: compound 3; then compounds 1 and 2 (each within the scatter of the next).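

Swapping thiophen-3-yl for thiophen-2-yl on the saturated ring carbon gives, in this assay, a number 15 percentage points lower from compound 1 to compound 3 (beyond the scatter), even though the two groups have the same atoms and differ only in how they are joined to the core. The earlier ester step stayed within the scatter, so this is the first change shown here that can be told apart from repeat-to-repeat variation, and it shows that the read-out can respond to the attachment point of the thiophene, though the step is modest. Nothing measured here explains this difference.

Going by these compounds, it remains open whether thiophen-2-yl would give a similar step alongside the ethyl ester of compound 2. A phenyl or furan-2-yl ring at this same ring carbon could also show whether other aromatic rings read higher or lower.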